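From Oxan-4-yl to Isopropyl on a Shared Core

The source may hold more compounds than are shown below. What is called first, only, known or untested is meant among the compounds shown, and "the series" means these compounds.

Compound 1 `CC(=O)N1CCN([C@H]2CC[C@H](Nc3ncnn4ccc(C(C)C)c34)CC2)CC1`: 2.4
Compound 2 `Cc1ccn2ncnc(N[C@H]3CC[C@H](N(C)C)CC3)c12`: 0.2
Compound 3 `CN(C)[C@H]1CC[C@H](Nc2ncnn3ccc(C4CCOCC4)c23)CC1`: 0.5

These numbers come from a physicochemical assay for lipophilicity, using the shake flask method, at pH 7.4; on this read-out higher numbers stand for higher lipophilicity and lower numbers for lower lipophilicity. Compound 3 stands at 0.5, far under compound 1 and within the scatter of compound 2. Among the compounds with values here, the one measured step that touches it is a number 0.30 log units higher from compound 2 to compound 3 (within the scatter), with oxan-4-yl in place of methyl on an aromatic carbon.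

Compound 4 `CC(C)c1ccn2ncnc(N[C@H]3CC[C@H](N(C)C)CC3)c12` differs from compound 3 in one place: isopropyl in place of oxan-4-yl on an aromatic carbon. In words, this is isopropyl in place of oxan-4-yl on an aromatic carbon. Within the data shown here, no measured step makes this exact exchange, so the evidence is indirect. The step above shows that one swap at this same place stayed within the scatter. Isopropyl has been measured only in compound 1, at 2.4, and that compound also differs from compound 4 in another part, so its number cannot be carried over as a step. Taken together, these data point to a moderate rise in this assay, not a jump to the level of compound 1, and the uncertainty is wide. The estimated change is a number 0.50 log units higher from compound 3 to compound 4 (beyond the scatter). For compound 4 the estimate is 1, with an expected range from 0.5 to 1.5.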

Compound 4, distribution coefficient: 1.3
Beside the measured number, compound 4's estimate is 0.30 log units below it, within the range that was stated.
By their numbers in this assay, from the lowest: compounds 2 and 3 (each within the scatter of the next); then compound 4; then compound 1.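

In this assay, within the data shown here, the aromatic carbon two ring bonds from the ring nitrogen proves able to move the number, since isopropyl in place of oxan-4-yl gives a number 0.80 log units higher from compound 3 to compound 4 (beyond the scatter), whereas the only earlier swap at this place stayed within the scatter. Isopropyl in place of methyl gives a step of similar direction, a number 1.10 log units higher from compound 2 to compound 4 (beyond the scatter), so with dimethylamino held fixed, methyl and oxan-4-yl sit within the scatter of each other and isopropyl stands clear of both. With isopropyl held fixed, the saturated ring carbon matters as well, as dimethylamino in place of 4-acetylpiperazin-1-yl gives a number 1.10 log units lower from compound 1 to compound 4 (beyond the scatter), so the two places can each shift the number by a step beyond the scatter.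

Nothing in the data explains why these exchanges move the number as they do. Still open, going by these compounds, is whether the rise from oxan-4-yl to isopropyl goes with the loss of the ring or of its oxygen, a question that cyclohexyl at this aromatic carbon, which keeps a ring of carbon alone, would help to separate.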